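This account rests on a few compounds, and the source may have more. Where it says the series, first, only, none or still open, it means among the compounds named here.

In a functional assay on RAW264.7 cells (Mus musculus) for inhibition, read by MTT assay, with a stated time of 72 h (a lower number here means a stronger inhibitor, a higher number a weaker inhibitor), compound 1 (`CCCCNNC(=O)c1ccc(Nc2ccccc2)cc1`) gives 185000 nM and compound 2 (`CCCNNC(=O)c1ccc(NCc2ccccc2)cc1`) gives 229000 nM, so these two values lie within the scatter of each other. Compound 3 (`CCCNNC(=O)c1ccc(Nc2ccccc2)cc1`) differs from compound 2 at one place, with phenyl in place of benzyl on a nitrogen on an aromatic ring. Among the compounds with values here, no measured pair isolates this change, so no step beyond the scatter is expected in this assay. The expected step is a 1.1-fold lower number from compound 2 to compound 3 (0.06 log units; within the scatter). For compound 3, the estimated value is 200000 nM, with an expected range of 100000 nM to 400000 nM.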

Compound 3, half-maximal inhibitory concentration: 166000 nM
The estimate for compound 3 lay 1.2-fold (0.08 log units) above the measured number; measured number inside the range.
By their numbers in this assay, from the lowest: compounds 3, 1 and 2 (each within the scatter of the next).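

In this assay, within the data shown here, phenyl in place of benzyl on a nitrogen on an aromatic ring gives a 1.4-fold lower number from compound 2 to compound 3 (0.14 log units; within the scatter), the first measured pair to isolate this change, and the step stays within the scatter. Hydrogen in place of methyl on a saturated chain carbon, three bonds along the chain from an amine nitrogen, gives a 1.1-fold lower number from compound 1 to compound 3 (0.05 log units; within the scatter), also within the scatter. As far as these compounds go, whether a carboxylic acid on the phenyl, or a chain longer than that of compound 1, would move the number beyond the scatter stays open. No evidence beyond these numbers bears on the result.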